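Methyl to trifluoromethyl on the pyridyl ether

The source may report more compounds than this note shows. Statements on the series, on what has been measured and on what is new or still open speak of the compounds shown alone.

Within the data shown here, compound 3 `Cc1cccnc1Oc1ccc(CC2SC(=O)NC2=O)cc1` gives 1090 nM in a functional assay for agonist activity at Free fatty acid receptor 1 (Homo sapiens), read by FLIPR, in the presence of a further agent that is not named here (a lower number here means that less compound is needed, a higher number that more compound is needed for the effect), the lowest of the three numbers measured so far. Compound 1 `Cc1ccnc(Oc2ccc(CC3SC(=O)NC3=O)cc2)c1` gives 4280 nM, and compound 2 `O=C1NC(=O)C(Cc2ccc(OCc3ccccc3)cc2)S1` gives 6180 nM. The step of a 3.9-fold lower number from compound 1 to compound 3 (0.59 log units; beyond the scatter) is modest and beyond the scatter, as is a 5.7-fold lower number from compound 2 to compound 3 (0.75 log units; beyond the scatter), while a 1.4-fold higher number from compound 1 to compound 2 (0.16 log units; within the scatter) lies within the scatter. Compound 4 `O=C1NC(=O)C(Cc2ccc(Oc3ncccc3C(F)(F)F)cc2)S1` differs from compound 3 by trifluoromethyl in place of methyl on an aromatic carbon. Among the measured compounds shown here, none of the measured steps alters a substituent on the ring with 1 nitrogen in this way: they either exchange the whole group on the oxygen or shift the methyl, so no step bears directly on the size of this change. For compound 4 the expected step is a 1.4-fold lower number from compound 3 to compound 4 (0.13 log units; within the scatter), which may well stay within the scatter. Compound 4 is estimated at 800 nM in this assay, with a range from 200 nM to 3000 nM.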

Compound 4, half-maximal effective concentration: 2290 nM
Estimate against measurement, compound 4: 2.9-fold (0.46 log units) below; measured number inside the range.
By their numbers in this assay, from the lowest: compound 3; then compounds 4, 1 and 2 (each within the scatter of the next, the first and the last beyond it).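

With a 2.1-fold higher number from compound 3 to compound 4 (0.32 log units; beyond the scatter) in this assay, the series gains its first step that keeps the ether and the place of the substituent and alters only the substituent itself, on the aromatic carbon ortho to a large group and two atoms from the ring nitrogen. At this carbon, the exchange of methyl, with 1 heavy atom, for trifluoromethyl, with 4 heavy atoms, does not lower the number, so methyl remains the better of the two here, though the step is only modest. Nothing among the data explains this difference.

A single pair cannot show whether the number at this carbon follows the size of the group, and a chlorine atom, an ethyl group or a methoxy group there would test that. As far as these compounds go, it also remains open whether trifluoromethyl would give a step of similar size and direction at the place that carries methyl in compound 1.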